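The source may hold more compounds than are shown below. What is called first, only, known or untested is meant among the compounds shown, and "the series" means these compounds.

Compound 1 `COc1cc(C(c2ccc(O)c(OC)c2)[C@@H](C)[C@H](C)CF)ccc1O`: 32000 nM
Compound 2 `COc1ccc(C(c2ccc(OC)c(OC)c2)[C@H](C)[C@@H](C)CO)cc1OC`: 47000 nM
Compound 3 `COc1ccc(C(c2ccc(OC)c(OC)c2)[C@H](C)[C@H](C)CO)cc1OC`: > 100000 nM

In a functional assay on HL-60 cells (Homo sapiens) for cytotoxicity, read by WST assay, with a stated time of 48 h (a lower number here means a stronger inhibitor, a higher number a weaker inhibitor), compound 1 gives the lowest of the two numbers shown, with compound 2 within the scatter of it. Compound 3 gives only a limit in this assay. Among the measured compounds shown here, the one measured step, an at least 2.1-fold higher number from compound 2 to compound 3 (0.32 log units; beyond the scatter), turns on the fact that compounds 2 and 3 differ only in the configuration as drawn and does not touch the change now followed. Compound 4 `COc1cc(C(c2ccc(O)c(OC)c2)[C@H](C)[C@H](C)CO)ccc1O` differs from compound 1 by 2-(hydroxymethyl)-1-methylpropyl in place of 2-(fluoromethyl)-1-methylpropyl on a saturated chain carbon bound to two aromatic carbons. For the measured compounds named here, no measured step covers this exchange, and the two hydroxymethyl compounds 2 and 3 both sit at weak values, so the expectation is for no step beyond the scatter, or a modest rise. Compound 4 is therefore estimated at 45000 nM, within 15000 nM to 100000 nM, a step of a 1.4-fold higher number from compound 1 to compound 4 (0.15 log units; within the scatter).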

Compound 4, half-maximal inhibitory concentration: > 100000 nM
Compound 4 was reported as a limit; the forecaster's own chance of this, stated with the estimate: 25%; middle value at least 2.2-fold (0.34 log units) away from the limit.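

In this assay, 2-(hydroxymethyl)-1-methylpropyl in place of 2-(fluoromethyl)-1-methylpropyl on a saturated chain carbon bound to two aromatic carbons gives an at least 3.1-fold higher number from compound 1 to compound 4 (0.49 log units; beyond the scatter). Compound 4 gives > 100000 nM, which is a limit of the assay. Among the compounds shown here, the only earlier step rested on something else: the fact that compounds 2 and 3 differ only in the configuration as drawn.

The compounds shown leave open whether a chain ending in an amine or a methyl ether would sit nearer compound 1 or compound 4. How far compound 4 lies from compound 1 also stays open, given: the limit of > 100000 nM in this assay, at which 2 of the 4 values shown sit.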